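A few compounds are considered here, and "the series" means these few. Any claim that something is new, unique, unknown or untested is made for them only; others in the source may bear on it.

Of the compounds shown here, two have been measured in a functional assay on the whole organism with Rattus norvegicus as the target, at a dose of 100 mg/kg; on this read-out higher numbers stand for more inhibition at the one dose given (going by the name of the read-out) and lower numbers for less inhibition. Compound 1 `C/N=C(/NC#N)NCCCCn1nc(N(C)C)ccc1=O` gives 26.3% in this assay. Compound 2 `CC/N=C(\S)NCCCCCCn1nc(-c2ccccc2)ccc1=O` gives -5.6% in this assay, the lowest of the two numbers; the gap to compound 1 lies beyond the scatter. Compound 3 `C/N=C(/NC#N)NCCCCCCn1nc(-c2ccccc2)ccc1=O` has not been measured. It differs from compound 2 in one place: a group of 6 heavy atoms (3 carbon, 3 nitrogen; no ring) in place of a group of 5 heavy atoms (3 carbon, 1 nitrogen, 1 sulfur; no ring), on an amine nitrogen. For the measured compounds named here, the group that enters is the same tail that compound 1 carries, though compound 1 otherwise differs from compound 3 in the length of the chain and in the group on the core, so no single step isolates this change. On this thin basis an increase is expected from compound 2 to compound 3, about a number 20.6 percentage points higher from compound 2 to compound 3 (beyond the scatter) in this assay, with wide uncertainty. For compound 3 the expected value in this assay is 15%, somewhere between -10% and 40%.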

Compound 3, a percentage reported as inhibition, in the whole organism at one dose (the size of the read-out at that dose, not a potency): 31.7%
Beside the measured number, compound 3's estimate is 16.7 percentage points below it; measured number inside the range.
By their numbers in this assay, from the lowest: compound 2; then compounds 1 and 3 (each within the scatter of the next).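

For the compounds shown here, the exchange on the amine nitrogen gives a number 37.3 percentage points higher from compound 2 to compound 3 (beyond the scatter) in this assay, the first change that can be read at a single place. It shows that, with the saturated chain and the rest of the molecule held constant, the group at this position has a large effect on the read-out at the one dose given. The group with 3 nitrogen atoms gives a clearly higher number than the sulfur-bearing group it replaces, although nothing shown explains the difference.

The compounds shown leave open which part of the entering group matters, as a urea at this position would separate the nitrile-bearing tail from the simple presence of a polar group. They also leave open whether the step would hold on a shorter chain.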